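This account rests on a few compounds, and the source may have more. Where it says the series, first, only, none or still open, it means among the compounds named here.

Working notes on the series. The shared core appears in compound 1 `Cc1cc(NNC(=O)Nc2cc(Cl)nc(Cl)c2)ncc1C#N`, compound 2 `Cc1cc(C#N)nc(NNC(=O)Nc2cc(Cl)nc(Cl)c2)c1` and compound 3 `Cc1cc(NNC(=O)Nc2cc(Cl)nc(Cl)c2)ncc1-c1cn(C)nc1C`, each measured in a functional assay on CHO cells for agonist activity at sphingosine 1-phosphate receptor 2 (Homo sapiens), read by fluorescence and calcium flux, with a stated time of 3 min; a higher number here means a weaker inhibitor, a lower number a stronger inhibitor. In this assay compound 1 gives > 23000 nM, which is a limit of the assay and not a number. Compound 2 likewise reaches only a limit in this assay, > 23000 nM. Compound 3 also stops at a limit, > 23000 nM. All three values therefore sit at the limit of > 23000 nM in this assay, at which 3 of the 3 values shown sit, and compound 2 stands at that limit with nothing more known about it.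

Among the measured compounds shown here, the one step between compounds differing in a single place, a step that the two limits leave unreadable from compound 1 to compound 3, cannot be read because both of its ends sit at the limit of > 23000 nM in this assay, at which 3 of the 3 values shown sit.

Compound 4 `Cc1cc(NNC(=O)Nc2cc(Cl)nc(Cl)c2)nc(-c2ccc(F)cc2)c1` differs from compound 2 by 4-fluorophenyl in place of cyano on an aromatic carbon. For the measured compounds named here, no measured step with a readable size bears on this change, so no direction can be drawn from the series. Compound 4 is expected to give 23000 nM, with a range from 5000 nM to 100000 nM. The step from compound 2 to compound 4 is estimated as a number no higher from compound 2 to compound 4 (the limit leaves the size open), most probably again a limit rather than a number.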

Compound 4, half-maximal inhibitory concentration: > 23000 nM
Compound 4 gave a limit, no number; the forecaster's own chance of this, stated with the estimate: 80%; the middle value sits exactly at the limit.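

In this assay compound 4 gives > 23000 nM which is a limit of the assay and not a number. The step from compound 2 to compound 4 cannot be read, as every value sits at one limit: (the limit of > 23000 nM in this assay, at which 4 of the 4 values shown sit). The compounds shown leave open whether any change on the shared core gives a readable value in this assay at all.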